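This account rests on a few compounds, and the source may have more. Where it says the series, first, only, none or still open, it means among the compounds named here.

Among the three compounds already measured, compound 3 `COc1ccc(S(=O)(=O)N[C@H]2CCN(CCCOc3ccc(C(=O)C4CC4)cc3)C2)cc1` stands lowest: in an assay on isolated protein for binding affinity to histamine H2 receptor (Homo sapiens) (a higher number here means a weaker inhibitor, a lower number a stronger inhibitor), compound 3 gives 1000 nM. Compound 1 `CC(=O)c1ccc(OCCCN2CC[C@H](NC(=O)c3ccc(C#N)cc3)C2)cc1` gives 6100 nM in this assay, and compound 2 `CC(=O)c1ccc(OCCCN2CC[C@H](NC(=O)[C@@H](N)CO)C2)cc1` gives 22000 nM. Within the data shown here, the only recorded step, a 3.6-fold higher number from compound 1 to compound 2 (0.56 log units; beyond the scatter), concerns the group on the carbonyl carbon. Among the measured compounds shown here, compound 4 `CC(C)(C)c1ccc(S(=O)(=O)N[C@H]2CCN(CCCOc3ccc(C(=O)C4CC4)cc3)C2)cc1` differs from compound 3 by tert-butyl in place of methoxy on an aromatic carbon, a change at another part of the molecule, so no measured step bears on it directly. For the measured compounds named here, with nothing among the measured compounds pointing either way, compound 4 is expected to stay close to compound 3 in this assay, and compound 4 is estimated at 800 nM, within 250 nM to 2500 nM. The step expected in this assay is a 1.3-fold lower number from compound 3 to compound 4 (0.10 log units; within the scatter).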

Compound 4, inhibition constant: 730 nM
Compound 4: middle estimate off by 1.1-fold (0.04 log units), on the high side; the range from low to high includes it.
By their numbers in this assay, from the lowest: compounds 4 and 3 (each within the scatter of the next); then compound 1; then compound 2.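

In this assay, tert-butyl in place of methoxy on an aromatic carbon para to a large group gives a 1.4-fold lower number from compound 3 to compound 4 (0.14 log units; within the scatter), so this position tolerates the change. Tert-butyl, with no hydrogen-bond acceptor, serves here as well as methoxy, with one, and the acceptor count at this position makes no difference that can be told from the scatter. Nothing available accounts for this result. Going by these compounds, whether an amine or a carboxylic acid on this carbon would leave the number unchanged stays open. So does the effect of a longer chain there.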